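A few compounds are considered here, and "the series" means these few. Any claim that something is new, unique, unknown or untested is made for them only; others in the source may bear on it.

Working notes on the series, distribution coefficient.

The set comprises compound 1 `CCOc1ccccc1-c1ccc(-c2nc3cnccc3c(N[C@H](CC)C(=O)N(C)C)c2C#N)cc1`, compound 2 `CC[C@@H](Nc1c(C#N)c(-c2ccc(-c3ccc(F)cc3)cc2)nc2cnccc12)C(N)=O` and compound 3 `CCOc1ccccc1-c1ccc(-c2nc3cnccc3c(NC(C(N)=O)C3CC3)c2C#N)cc1`; compound 4 `CC[C@@H](Nc1c(C#N)c(-c2ccc(-c3ccccc3CO)cc2)nc2cnccc12)C(N)=O` is not yet measured. In a physicochemical assay for lipophilicity, read by HPLC, at pH 7.5 (a higher number here means a more lipophilic compound, a lower number a more polar compound), compound 1 gives 3.7, compound 2 gives 2.7 and compound 3 gives 3. Compound 2 holds the lowest of the three numbers; compound 3 lies nearest to it, within the scatter, while compound 1 lies furthest, beyond the scatter. For the measured compounds named here, the only single-point step measured so far is a number 0.70 log units lower from compound 1 to compound 3 (beyond the scatter), a change on the amine nitrogen of the shared core.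

Compound 4 differs from compound 2 on an aromatic carbon of a six-membered aromatic ring of carbon only: 2-(hydroxymethyl)phenyl in place of 4-fluorophenyl on an aromatic carbon. Going by the values given here, no measured step alters this ring. Compounds 1 and 3 carry a different group there and also differ from compound 2 in a second place, so their values give no clean comparison, and the step on the amine nitrogen does not bear on the change. The change swaps a fluorine for a hydroxymethyl group, and in this assay a step downward is expected, a number 0.80 log units lower from compound 2 to compound 4 (beyond the scatter), beyond the scatter. Compound 4 is therefore estimated at 1.9, with a range of 1.4 to 2.5.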

Compound 4, distribution coefficient: 2.1
Compound 4: the middle estimate sits 0.20 log units below what was measured; the measured number falls inside the stated range.
By their numbers in this assay, from the lowest: compound 4; then compounds 2 and 3 (each within the scatter of the next); then compound 1.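

For the compounds shown here, the step at this position is the first to touch the outer aromatic ring: in this assay, 2-(hydroxymethyl)phenyl in place of 4-fluorophenyl gives a number 0.60 log units lower from compound 2 to compound 4 (beyond the scatter), so a change at this aromatic carbon, para to a large group, moves the read-out by more than the scatter. Going by these compounds alone, until now, the only single-point step lay on the amine nitrogen, and this result shows that the read-out also responds to a change at the far end of the molecule. The exchange alters several things at once, since the entering group has 1 hydrogen-bond donor and 1 hydrogen-bond acceptor where the leaving group has 0 of each, and no measurement available here accounts for the size of the step.

Within the data shown here, the single step cannot separate the loss of the fluorine from the gain of the hydroxymethyl group, nor the effect of that group's place on the ring from the effect of its identity. The compounds shown also leave open how the value would respond to 4-(hydroxymethyl)phenyl, to a plain phenyl, or to an aminomethyl or carboxylic acid group on the same ring.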